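Swapping Bromine for Chlorine on a Salicylanilide Core

A few compounds are considered here, and "the series" means these few. Any claim that something is new, unique, unknown or untested is made for them only; others in the source may bear on it.

Measured compounds:
compound 1 `O=C(Nc1cc(C(F)(F)F)cc(C(F)(F)F)c1)c1ccc(Br)cc1O`: 830 nM
compound 2 `O=C(Nc1cc(C(F)(F)F)cc(C(F)(F)F)c1)c1ccc(Cl)cc1O`: 620 nM
compound 3 `N#Cc1ccc(NC(=O)c2cc(Br)c(-c3ccccc3)cc2O)cc1`: 850 nM

All three were tested in a functional assay on KG-1 cells (Homo sapiens) for cytotoxicity, read by luminescence and CellTiter-Glo, with a stated time of 3 days; a lower number here means a stronger inhibitor, a higher number a weaker inhibitor. Compound 1 and compound 2 share one core and differ only by chloro in place of bromo on an aromatic carbon. That change gave a 1.3-fold lower number from compound 1 to compound 2 (0.13 log units; within the scatter). Compound 3 has a different core, and how it differs from the core of compound 1 is not broken down here. Compound 4 `N#Cc1ccc(NC(=O)c2cc(Cl)c(-c3ccccc3)cc2O)cc1` has not yet been measured in this assay; it differs from compound 3 by chloro in place of bromo on an aromatic carbon. Among the measured compounds shown here, this is the same kind of change as the one from compound 1 to compound 2, but the surroundings differ: in compound 2 the chloro is meta to a hydroxy group and para to a large group, whereas in compound 4 it is ortho to a phenyl group, meta to a large group and para to a hydroxy group. Because the step of a 1.3-fold lower number from compound 1 to compound 2 (0.13 log units; within the scatter) stayed within the scatter, a step of about a 1.2-fold lower number from compound 3 to compound 4 (0.08 log units; within the scatter) is expected for compound 4, with the caveat that it rests on a single pair. Compound 4 is estimated at 700 nM, expected between 350 nM and 1400 nM.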

Compound 4, half-maximal inhibitory concentration: 480 nM
For compound 4 the middle estimate is 1.5-fold (0.16 log units) above the measured one; the range from low to high includes it.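

In this assay, chloro in place of bromo gave a 1.8-fold lower number from compound 3 to compound 4 (0.25 log units; within the scatter), which means that on this second core, too, the swap stayed within the usual scatter. Set side by side, the two steps agree: the same change on two cores in this assay, a 1.3-fold lower number (0.13 log units; within the scatter) from compound 1 to compound 2 and a 1.8-fold lower number (0.25 log units; within the scatter) from compound 3 to compound 4, 1.3-fold (0.12 log units) apart, within the scatter of two such steps. This shows that the swap behaved alike on these two cores, but both steps are small, and two pairs neither establish that chloro really differs from bromo here nor predict the result on a further core.

From the compounds shown here alone, it remains open whether a group of another kind at this place, such as a methyl or an amine, would move the number beyond the scatter. Going by these compounds, the effect of the swap on any other core also remains open.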